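A new aryl group on the double bond of compound 2

A few compounds are considered here, and "the series" means these few. Any claim that something is new, unique, unknown or untested is made for them only; others in the source may bear on it.

Compound 1 `O=C(O)c1ccc(C(=O)/C(=C\c2ccc(F)c([N+](=O)[O-])c2)SCc2ccc(Cl)cc2)cc1` gives 50000 nM in a functional assay on DU-145 cells (Homo sapiens) for inhibition, read by trypan blue exclusion, with a stated time of 96 h; on this read-out lower numbers stand for stronger inhibition of growth and higher numbers for weaker inhibition of growth.
Compound 2 `O=C(O)c1ccc(C(=O)/C(=C\c2ccc(F)c([N+](=O)[O-])c2)SCc2ccc(F)cc2)cc1` gives 1000 nM.
Compound 3 `O=C(O)c1ccc(C(=O)/C(=C\c2ccc(F)c([N+](=O)[O-])c2)SCc2ccc(C(F)(F)F)cc2)cc1` gives 1000 nM.

Among these three, compound 2 stands level with compound 3 at the digits printed, the two together giving the lowest numbers, while compound 1 lies far above them, as the step of a 50-fold lower number from compound 1 to compound 2 (1.70 log units; beyond the scatter) shows; the step of no change at the digits printed from compound 2 to compound 3 (within the scatter) is within the scatter. Compound 4 `CN(C)c1ccc(/C=C(/SCc2ccc(F)cc2)C(=O)c2ccc(C(=O)O)cc2)cc1` is not yet measured. It differs from compound 2 in this way: 4-(dimethylamino)phenyl in place of 4-fluoro-3-nitrophenyl on a double-bonded chain carbon bound to a double-bonded chain carbon. The measured steps all concern the substituent on the benzyl thioether, so none of them speaks directly to the aryl group on the double-bonded chain carbon. The measured compounds are therefore a poor guide for the direction or size of this change in this assay. Among the measured compounds shown here, with no step bearing on it, the expectation for compound 4 is a number near that of compound 2, with a wide range to either side. Compound 4 is estimated at 1500 nM, between 150 nM and 15000 nM, which would mean the step of a 1.5-fold higher number from compound 2 to compound 4 (0.18 log units; within the scatter).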

Compound 4, concentration for 50% growth inhibition: 10000 nM
Compound 4: middle estimate off by 6.7-fold (0.82 log units), on the low side; low and high end bracket the measured number.
By their numbers in this assay, from the lowest: compounds 2 and 3 (each within the scatter of the next); then compound 4; then compound 1.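

The aryl group on the double-bonded chain carbon is not a silent part of these molecules in this assay: with the benzyl thioether held as in compound 2, placing 4-(dimethylamino)phenyl where 4-fluoro-3-nitrophenyl stood gives a 10-fold higher number from compound 2 to compound 4 (1.00 log units; beyond the scatter), a step beyond the scatter. Among the compounds shown here, the earlier steps all concerned the substituent on the benzyl thioether, so this is the first sign that the read-out also answers to a change at this second place, and here the change goes towards weaker inhibition of growth. Nothing available accounts for the size or direction of this step.

The swap removes the fluoro and the nitro groups and brings in the dimethylamino group in a single move, so the compounds shown leave open which of these differences carries the step, and whether a plain phenyl group or a methoxy-bearing phenyl group at this place would fall nearer compound 2 or compound 4. They also leave open whether the same aryl change would act alike with the trifluoromethyl substituent of compound 3 on the benzyl thioether.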